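Cyano to Trifluoromethyl: an Expected Cytotoxicity Reading

The compounds below may be only part of what the source reports. "The series", "measured", "known", "first", "only" and "open" are said of these compounds alone.

Three analogues on a shared core differ only in the aryl group. In an ADME assay on Huh-7 cells (Homo sapiens) for cytotoxicity, read by MTT assay, with a stated time of 48 h (on this read-out higher numbers stand for lower toxicity in this test and lower numbers for higher toxicity in this test), compound 1 `CN(C)CCCCOC(=O)Nc1ccc(Cn2nc(-c3cncnc3)c3ccccc3c2=O)cc1` gives 65300 nM, compound 2 `CN(C)CCCCOC(=O)Nc1ccc(Cn2nc(-c3cccc(F)c3)c3ccccc3c2=O)cc1` gives 37400 nM, and compound 3 `CN(C)CCCCOC(=O)Nc1ccc(Cn2nc(-c3ccccc3C#N)c3ccccc3c2=O)cc1` gives 90700 nM, the largest of the three numbers. The steps of a 1.4-fold higher number from compound 1 to compound 3 (0.14 log units; within the scatter) and a 1.7-fold lower number from compound 1 to compound 2 (0.24 log units; within the scatter) both lie within the scatter, while a 2.4-fold higher number from compound 2 to compound 3 (0.38 log units; beyond the scatter) is modest. Compound 4 `CN(C)CCCCOC(=O)Nc1ccc(Cn2nc(-c3ccccc3C(F)(F)F)c3ccccc3c2=O)cc1` carries trifluoromethyl in place of cyano on an aromatic carbon. Among the measured compounds shown here, no measured step changes this one position, and the aryl exchanges seen so far moved this assay only a little, so the expected step of a 1.1-fold lower number from compound 3 to compound 4 (0.05 log units; within the scatter) is not beyond the scatter. Compound 4 is therefore estimated at 80000 nM, with a range from 40000 nM to 160000 nM.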

Compound 4, half-maximal cytotoxic concentration: 35700 nM
Compound 4: the middle estimate sits 2.2-fold (0.35 log units) above what was measured; the measured number lies below the stated range.
By their numbers in this assay, from the lowest: compounds 4, 2, 1 and 3 (each within the scatter of the next, the first and the last beyond it).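

In this assay, trifluoromethyl in place of cyano on an aromatic carbon ortho to a large group gives a modest change, with a 2.5-fold lower number from compound 3 to compound 4 (0.40 log units; beyond the scatter), so a swap confined to this one position can carry the number beyond the scatter. The other comparisons, a 1.0-fold lower number from compound 2 to compound 4 (0.02 log units; within the scatter) and a 1.8-fold lower number from compound 1 to compound 4 (0.26 log units; within the scatter), both lie within the scatter, leaving compound 4 level with compound 2 and compound 1. Nothing measured here accounts for the step between the nitrile and trifluoromethyl. What the compounds shown leave open is how a methoxy group, a chlorine atom or an amine at this same position would read.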